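The compounds below may be only part of what the source reports. "The series", "measured", "known", "first", "only" and "open" are said of these compounds alone.

Working notes on the series. Compound 1 `COc1cc(Cl)ccc1C(=O)Nc1ccc(Cl)cc1O` and compound 2 `COc1cc(Cl)ccc1C(=O)Nc1ccc(Br)cc1O` share one core; in a functional assay on HepG2 cells (Homo sapiens) for cytotoxicity, with a stated time of 24 h (on this read-out lower numbers stand for stronger inhibition and higher numbers for weaker inhibition), compound 1 gives 7340 nM and compound 2 gives 46600 nM. The change between them, (bromo in place of chloro on an aromatic carbon), gave a 6.3-fold higher number from compound 1 to compound 2 (0.80 log units; beyond the scatter). Compound 3 `COc1ccc(Cl)cc1C(=S)Nc1ccc(Cl)cc1O` rests on a second core; how the two cores differ is not broken down here. In this assay compound 3 gives 4450 nM, the lowest of the three numbers, though its gap to compound 1 lies within the scatter. Compound 4 `COc1ccc(Cl)cc1C(=S)Nc1ccc(Br)cc1O` is not yet measured. It carries the same change on the second core, (bromo in place of chloro on an aromatic carbon). Since the step from compound 1 to compound 2 was a 6.3-fold higher number from compound 1 to compound 2 (0.80 log units; beyond the scatter), a step of similar size is expected, a 4.9-fold higher number from compound 3 to compound 4 (0.69 log units; beyond the scatter), resting on that single earlier step alone. Compound 4 is therefore estimated at 22000 nM, between 7000 nM and 60000 nM.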

Compound 4, half-maximal inhibitory concentration: 7600 nM
Beside the measured number, compound 4's estimate is 2.9-fold (0.46 log units) above it; measured number inside the range.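

On the core of compound 3, bromo in place of chloro gave a 1.7-fold higher number from compound 3 to compound 4 (0.23 log units; within the scatter) in this assay, so the step seen on the core of compound 1 did not carry over at its full size: the same change on two cores in this assay, a 6.3-fold higher number (0.80 log units; beyond the scatter) from compound 1 to compound 2 and a 1.7-fold higher number (0.23 log units; within the scatter) from compound 3 to compound 4, 3.7-fold (0.57 log units) apart, beyond the scatter of two such steps

Among the compounds shown here, only the step on the core of compound 1 lies beyond the scatter, so the step on the core of compound 3 cannot be read as a real change. With one pair on each core, this does not show which difference between the cores matters, or how the change would behave on any other core.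

The compounds shown leave open whether fluoro, a nitrile or an amine on the same aromatic carbon would also differ between the two cores. For the compounds shown here, they also hold no pair linking the two cores through a single change.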